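The source may hold more compounds than are shown below. What is called first, only, known or untested is meant among the compounds shown, and "the series" means these compounds.

Measured compounds in an assay on HEK293 cells for inhibition of acid ceramidase (Rattus norvegicus), read by LC-MS, with a stated time of 30 min; on this read-out higher numbers stand for weaker inhibition and lower numbers for stronger inhibition:
- compound 1 `CCCCCCNC(=O)n1cc(C#N)c(=O)[nH]c1=O`: no result reported
- compound 2 `CCCCCCNC(=O)n1cc(F)c(=O)n(C)c1=O`: 13 nM
- compound 3 `CCCCCCNC(=O)n1ccc(=O)n(C)c1=O`: 53 nM

Compound 2 holds the lowest of the two numbers in this assay; the nearest entry, compound 3, differs by a 4.1-fold higher number from compound 2 to compound 3 (0.61 log units; beyond the scatter), a step that swaps hydrogen for fluoro on an aromatic carbon. Compound 1 carries no number and gives no guidance.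

Compound 4 `CCCCCCNC(=O)n1cc(F)c(=O)n(C(=O)c2ccccc2)c1=O` is the unmeasured entry. It differs from compound 2 by benzoyl in place of methyl on an aromatic nitrogen. Among the compounds with values here, no measured step touches the methyl-bearing ring nitrogen; the single known step concerns the fluoro on carbon, which compound 4 keeps. Within the data shown here, there is therefore no directly relevant precedent, and the expectation for compound 4 must be broad, centred near the value of compound 2 13 nM.

For compound 4 the estimate is 30 nM, with a range from 6 nM to 150 nM.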

Compound 4, half-maximal inhibitory concentration: 20 nM
Beside the measured number, compound 4's estimate is 1.5-fold (0.18 log units) above it; measured number inside the range.
By their numbers in this assay, from the lowest: compounds 2 and 4 (each within the scatter of the next); then compound 3.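

In this assay, within the data shown here, benzoyl in place of methyl on the aromatic nitrogen gives a 1.5-fold higher number from compound 2 to compound 4 (0.19 log units; within the scatter), the first reading at this position, since the earlier step concerned only the fluoro on carbon. The nitrogen therefore carries a group of 8 heavy atoms, with a six-membered aromatic ring and a carbonyl, and the number stays within the scatter of that of the methyl compound. No measurement here bears on why the two compounds read alike.

From the compounds shown here alone, whether an amine or a carboxylic acid on this nitrogen would read the same remains open. So does whether benzoyl reads the same with hydrogen in place of the fluoro.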